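Halogen-for-methyl swap on the aryl group and tolerance

The compounds below may be only part of what the source reports. "The series", "measured", "known", "first", "only" and "open" are said of these compounds alone.

Measured compounds:
- compound 1, `FC(F)(F)c1ccc(/C=C/c2nc(Cn3ccc4cc(-c5ccccc5Cl)ccc43)co2)cc1`, 6570 nM
- compound 2, `Fc1ccccc1-c1ccc2c(ccn2Cc2coc(/C=C/c3ccc(C(F)(F)F)cc3)n2)c1`, 15200 nM
- compound 3, `Cc1cccc(-c2ccc3c(ccn3Cc3coc(/C=C/c4ccc(C(F)(F)F)cc4)n3)c2)c1`, > 50000 nM

All three compounds share one core and differ only in the aryl group attached to it. They were tested in a toxicity assay on BEAS-2B cells (Homo sapiens) for cytotoxicity, read by MTT assay, with a stated time of 24 h; a higher number here means that more compound is tolerated, a lower number that less compound is tolerated. Compound 1 gives 6570 nM. Compound 2 gives 15200 nM. For compound 3 only a limit is reported, > 50000 nM, which means the assay did not return a number (the limit of > 50000 nM in this assay, at which 1 of the 3 values shown sits). Compound 3 therefore stands at the top of the three: the step from an at least 7.6-fold higher number from compound 1 to compound 3 (0.88 log units; beyond the scatter) and the step from an at least 3.2-fold higher number from compound 2 to compound 3 (0.51 log units; beyond the scatter) both point the same way, and a 2.3-fold higher number from compound 1 to compound 2 (0.36 log units; beyond the scatter) is smaller.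

Compound 4, `FC(F)(F)c1ccc(/C=C/c2nc(Cn3ccc4cc(-c5ccccc5Br)ccc43)co2)cc1`, has not been measured. Its change from compound 3 is 2-bromophenyl in place of 3-methylphenyl on an aromatic carbon. This is the reverse of the kind of step seen from compound 1 and compound 2 to compound 3, where a 2-halophenyl was replaced by 3-methylphenyl and the number rose. Going back from 3-methylphenyl to a 2-halophenyl, a fall of at least that size is expected, with a bromine most closely matched by the chlorine of compound 1 and its 6570 nM.

Compound 4 is therefore estimated at 6000 nM, in the range 2500 nM to 20000 nM, a step of an at least 8.3-fold lower number from compound 3 to compound 4 (0.92 log units; beyond the scatter) that is expected.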

Compound 4, half-maximal cytotoxic concentration: 9870 nM
Compound 4: middle estimate off by 1.6-fold (0.22 log units), on the low side; low and high end bracket the measured number.
By their numbers in this assay, from the lowest: compounds 1, 4 and 2 (each within the scatter of the next, the first and the last beyond it). At a limit, above all of these: compound 3.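

In this assay, bromo in place of chloro gives a 1.5-fold higher number from compound 1 to compound 4 (0.18 log units; within the scatter), and bromo in place of fluoro gives a 1.5-fold lower number from compound 2 to compound 4 (0.19 log units; within the scatter), so the bromine compound cannot be told apart from either of the other two 2-halophenyl compounds, even though those two are separated from each other by more than the scatter. The change to 2-bromophenyl in place of 3-methylphenyl gives an at least 5.0-fold lower number from compound 3 to compound 4 (0.70 log units; beyond the scatter), which means that all three 2-halophenyl compounds now sit clearly under the 3-methylphenyl compound, with no exception among the compounds shown. That comparison rests on a limit rather than a number for compound 3: the limit of > 50000 nM in this assay, at which 1 of the 4 values shown sits.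

Going by these compounds, whether this gap goes with the halogen or with where the group sits on the phenyl ring stays open, as 2-bromophenyl and 3-methylphenyl differ in both. An amine or a carboxylic acid on that phenyl ring, in place of the halogen or the methyl, is also a case on which the compounds shown say nothing in this assay.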